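Furan-2-yl to 1H-pyrrol-2-yl: the next step

This account rests on a few compounds, and the source may have more. Where it says the series, first, only, none or still open, it means among the compounds named here.

Compound 1 `CC1=CC[C@H](C(C)(C)NC(=S)N/N=C/c2ccc(O)cc2)CC1` — in a functional assay on HT-29 cells (Homo sapiens) for inhibition, read by sulforhodamine B assay, with a stated time of 48 h (a lower number here means a stronger inhibitor of growth, a higher number a weaker inhibitor of growth), compound 1 reaches only the limit > 100000 nM (the limit of > 100000 nM in this assay, at which 1 of the 2 values shown sits).
Compound 2 `CC1=CC[C@H](C(C)(C)NC(=S)N/N=C/c2ccco2)CC1` — in this assay compound 2 gives 7200 nM.

Among the measured compounds shown here, compound 2 thus holds the only number measured here. For the measured compounds named here, the single measured step, an at least 13-fold lower number from compound 1 to compound 2 (1.14 log units; beyond the scatter), is large. Compound 3 `CC1=CC[C@H](C(C)(C)NC(=S)N/N=C/c2ccc[nH]2)CC1` differs from compound 2 by 1H-pyrrol-2-yl in place of furan-2-yl on a carbon with a double bond to nitrogen. That measured step swapped a different ring at the same place, so it offers little guidance for this exchange of one five-membered ring for another; the step expected is a 1.1-fold higher number from compound 2 to compound 3 (0.05 log units; within the scatter), not beyond the scatter. Compound 3 is estimated at 8000 nM, within 2500 nM to 30000 nM.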

Compound 3, concentration for 50% growth inhibition: 27500 nM
For compound 3 the middle estimate is 3.4-fold (0.54 log units) below the measured one, and the stated range covers the measured number.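

In this assay, the choice of ring on a carbon with a double bond to nitrogen matters even between two five-membered aromatic rings with one hetero atom: 1H-pyrrol-2-yl in place of furan-2-yl gives a 3.8-fold higher number from compound 2 to compound 3 (0.58 log units; beyond the scatter). Set against 4-hydroxyphenyl, 1H-pyrrol-2-yl still gives an at least 3.6-fold lower number from compound 1 to compound 3 (0.56 log units; beyond the scatter). That comparison rests on a limit for compound 1: the limit of > 100000 nM in this assay, at which 1 of the 3 values shown sits.

The compounds shown leave open how a thiophen-2-yl or a pyridin-2-yl ring would compare at this place. They also do not tell why the two five-membered rings differ.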